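Swapping One Ring Substituent Set at an Assay Limit

The compounds below may be only part of what the source reports. "The series", "measured", "known", "first", "only" and "open" are said of these compounds alone.

Measured so far in a physicochemical assay for solubility (on this read-out lower numbers stand for lower solubility and higher numbers for higher solubility), each entry being a limit and not a number:

- Compound 1 `COC(=O)c1ccc(C(=O)/C(=C\c2ccc(F)c([N+](=O)[O-])c2)SCc2ccc(Br)cc2)cc1`: < 1000 ug/mL
- Compound 2 `O=C(O)c1ccc(C(=O)/C(=C\c2ccc(F)c([N+](=O)[O-])c2)S(=O)(=O)Cc2ccc(Br)cc2)cc1`: < 1000 ug/mL
- Compound 3 `COc1cc(/C=C(/SCc2ccc(Br)cc2)C(=O)c2ccc(C(=O)O)cc2)ccc1F`: < 1000 ug/mL

Compound 3 gives < 1000 ug/mL, which is a limit and not a number. The whole set so far comes down to the limit of < 1000 ug/mL in this assay, at which 3 of the 3 values shown sit. With only limits in hand, the three compounds cannot be ranked against one another.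

The next compound is compound 4 `O=C(O)c1ccc(C(=O)/C(=C\c2ccc([N+](=O)[O-])cc2F)SCc2ccc(Br)cc2)cc1`, which keeps the rest of compound 3 and changes one group. It carries 2-fluoro-4-nitrophenyl in place of 4-fluoro-3-methoxyphenyl on a double-bonded chain carbon bound to a double-bonded chain carbon.

For the measured compounds named here, no two measured compounds differ in just one place, so no earlier step can serve as a guide. In this assay no step beyond the usual scatter is expected, and no direction can be named with any confidence. The expected move, a step that the limit leaves unreadable from compound 3 to compound 4, is therefore only a rough estimate. The likeliest report is the same limit again. For compound 4 the estimated value is 600 ug/mL, with an expected range from 150 ug/mL to 1000 ug/mL.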

Compound 4, solubility: < 1000 ug/mL
Compound 4 was reported as a limit; the forecaster's own chance of this, stated with the estimate: 85%; the middle value is on the limit's open side.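

In this assay compound 4 gives < 1000 ug/mL, which is a limit and not a number. For the compounds shown here, compound 3 is also reported as a limit, and no step from compound 3 to compound 4 can be read. The compounds shown leave open how their solubilities compare, because every entry comes down to one shared value: the limit of < 1000 ug/mL in this assay, at which 4 of the 4 values shown sit.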